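Metabolic stability after a ring-substituent swap on the amide

The compounds below may be only part of what the source reports. "The series", "measured", "known", "first", "only" and "open" are said of these compounds alone.

Measured compounds in an ADME assay on microsomes from liver (Homo sapiens) for metabolic stability, with a stated time of 10 min; on this read-out lower numbers stand for a less stable compound and higher numbers for a more stable compound:
compound 1, `C[C@]1(C(=O)O)CC[C@H](C(=O)N2CC[C@](c3ccc(C(F)(C(F)(F)F)C(F)(F)F)cc3)(S(=O)(=O)c3ccc(F)cc3)C2)CC1`, gives 97%
compound 2, `CC[C@]1(C(=O)O)CC[C@H](C(=O)N2CC[C@](c3ccc(C(F)(C(F)(F)F)C(F)(F)F)cc3)(S(=O)(=O)c3ccc(F)cc3)C2)CC1`, gives 100%
compound 3, `C[C@]1(C(=O)N2CC[C@](c3ccc(C(F)(C(F)(F)F)C(F)(F)F)cc3)(S(=O)(=O)c3ccc(F)cc3)C2)CC[C@H](C(=O)O)CC1`, gives 80%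

Compound 1 stands second highest of the three numbers; compound 2 lies closest, with a number 3 percentage points higher from compound 1 to compound 2 (within the scatter), while compound 3 lies furthest, with a number 17 percentage points lower from compound 1 to compound 3 (beyond the scatter).

Compound 4, `COC[C@]1(C(=O)N2CC[C@](c3ccc(C(F)(C(F)(F)F)C(F)(F)F)cc3)(S(=O)(=O)c3ccc(F)cc3)C2)CC[C@H](C(=O)O)CC1`, has not yet been measured in this assay. It differs from compound 1 in one place: 4-carboxy-1-(methoxymethyl)cyclohexyl in place of 4-carboxy-4-methylcyclohexyl on a carbonyl carbon.

Among the compounds with values here, two measured steps bear on this change. The swap of the 4-carboxy-4-methylcyclohexyl for a 4-carboxy-1-methylcyclohexyl group gave a number 17 percentage points lower from compound 1 to compound 3 (beyond the scatter), and the same swap from the ethyl analogue gave a number 20 percentage points lower from compound 2 to compound 3 (beyond the scatter), both modest and beyond the scatter. Within the data shown here, compound 4 carries that same swap together with methoxymethyl where compound 3 has methyl; no measured pair shows the effect of that second part. A modest fall is therefore expected. From compound 1 the expected step is a number 22 percentage points lower from compound 1 to compound 4 (beyond the scatter). Compound 4 is estimated at 75%, with a range from 55% to 92%.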

Compound 4, percent of the compound remaining: 100%
Estimate against measurement, compound 4: 25 percentage points below, outside the stated range (above it).
By their numbers in this assay, from the lowest: compound 3; then compounds 1, 2 and 4 (each within the scatter of the next).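

In this assay, the fall seen with the 4-carboxy-1-methylcyclohexyl group of compound 3 does not extend to every group of this kind on the carbonyl carbon: the 4-carboxy-1-(methoxymethyl)cyclohexyl group gives a number 3 percentage points higher from compound 1 to compound 4 (within the scatter) and no change at the digits printed from compound 2 to compound 4 (within the scatter). Methoxy in place of hydrogen on the chain carbon, the single change separating these two ring arrangements' closest pair, gives a number 20 percentage points higher from compound 3 to compound 4 (beyond the scatter), so this small chain alone can decide whether the fall appears. Nothing measured here explains this difference.

The compounds shown leave open whether a hydroxymethyl or aminomethyl group in that place would behave like methoxymethyl. They also leave open whether a longer chain, such as ethoxymethyl, would give a number like that of compound 4 or that of compound 3.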